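The source may hold more compounds than are shown below. What is called first, only, known or untested is meant among the compounds shown, and "the series" means these compounds.

Working notes on the series.

Of the compounds shown here, three sharing one core have been measured in a functional assay on Caco-2 cells (Homo sapiens) for antiproliferative activity, read by MTT assay, with a stated time of 24 h; on this read-out higher numbers stand for weaker inhibition and lower numbers for stronger inhibition. Compound 1, `FC(F)(F)c1ccc(C2CC(c3ccccc3)=NN2c2ccc(-c3ccccc3)nn2)cc1`, gives 50000 nM. Compound 3, `FC(F)(F)c1ccc(C2CC(c3ccc(Cl)cc3)=NN2c2ccc(-c3ccccc3)nn2)cc1`, gives 10000 nM, the lowest number among the two numbers given. Compound 2, `COc1ccc(C2CC(c3ccccc3)=NN2c2ccc(-c3ccccc3)nn2)cc1`, reports only a limit of the assay, > 100000 nM, as the limit of > 100000 nM in this assay, at which 1 of the 3 values shown sits, states.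

The difference between the cores of compound 1 and compound 3 is chloro in place of hydrogen on an aromatic carbon; it gives a 5.0-fold lower number from compound 1 to compound 3 (0.70 log units; beyond the scatter). The change from compound 1 to compound 2 is methoxy in place of trifluoromethyl on an aromatic carbon; it gives an at least 2.0-fold higher number from compound 1 to compound 2 (0.30 log units; that floor lies within the scatter), the floor of that step lying within the scatter.

Compound 4, `COc1ccc(C2CC(c3ccc(Cl)cc3)=NN2c2ccc(-c3ccccc3)nn2)cc1`, is not yet measured. It differs from compound 3 by methoxy in place of trifluoromethyl on an aromatic carbon, the same change as from compound 1 to compound 2, made twice in all among these compounds, at the same place.

In this assay compound 4 is expected to show a 3.0-fold higher number from compound 3 to compound 4 (0.48 log units; beyond the scatter), resting on compound 3 at 10000 nM and on an at least 2.0-fold higher number from compound 1 to compound 2 (0.30 log units; that floor lies within the scatter). The estimate for compound 4 is 30000 nM, between 10000 nM and 100000 nM.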

Compound 4, half-maximal inhibitory concentration: > 100000 nM
Compound 4: no number, only a limit; the forecaster's own chance of this, stated with the estimate: 30%; at least 3.3-fold (0.52 log units) between middle value and limit.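

In this assay, methoxy in place of trifluoromethyl on the chloro-bearing core gives an at least 10-fold higher number from compound 3 to compound 4 (1.00 log units; beyond the scatter), so the change raises the number on this core as well, here beyond the scatter. For compound 4, the result of > 100000 nM is a limit of the assay and not a number. The change therefore points the same way on both cores, but no size can be carried from one core to the other, and the step between the two methoxy compounds cannot be read: the same change on two cores in this assay, an at least 2.0-fold higher number (0.30 log units; that floor lies within the scatter) from compound 1 to compound 2 and an at least 10-fold higher number (1.00 log units; beyond the scatter) from compound 3 to compound 4; the limit leaves it open whether they differ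

The compounds shown leave open how far the two methoxy compounds lie past the limit, and so whether chloro in place of hydrogen acts on the methoxy core as it does on the trifluoromethyl core. They also leave open what other groups at the same aromatic carbon, such as an amine or a carboxylic acid, would give in this assay.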